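This account rests on a few compounds, and the source may have more. Where it says the series, first, only, none or still open, it means among the compounds named here.

Measured compounds:
compound 1 `O=[N+]([O-])c1cccc(CNc2cc(Br)cc3[nH]ncc23)c1` — 1600 nM
compound 2 `O=[N+]([O-])c1cccc(CNc2cc(C(F)(F)F)cc3[nH]ncc23)c1` — 5170 nM
compound 3 `O=[N+]([O-])c1ccc2[nH]c(CNc3cc(C(F)(F)F)cc4[nH]ncc34)cc2c1` — a limit, > 100000 nM

Among the numbers given in an assay for inhibition of Tryptophan 2,3-dioxygenase (Homo sapiens), with stated times of 10 min and 60 min (a higher number here means a weaker inhibitor, a lower number a stronger inhibitor), compound 2 has the highest one; its nearest neighbour is compound 1, reached by the step of a 3.2-fold higher number from compound 1 to compound 2 (0.51 log units; beyond the scatter), which places trifluoromethyl in place of bromo on the shared core. The value of compound 3 is a limit of this assay, not a number (the limit of > 100000 nM in this assay, at which 1 of the 3 values shown sits). Compound 4 `OC1CCCC(Nc2cccc(CNc3cc(C(F)(F)F)cc4[nH]ncc34)c2)C1` differs from compound 2 in one place: (3-hydroxycyclohexyl)amino in place of nitro on an aromatic carbon. Among the measured compounds shown here, no measured step touches this position. For the measured compounds named here, the only step that has been measured, from compound 1 to compound 2, changes the core and not the group that is exchanged here, so it says little about the present change; the pair compound 2 and compound 3, whose second member sits at the limit, shows only that reworking the aryl portion can take the compound out of the measurable range. The expectation for compound 4 is therefore wide, with a likely move of a 1.7-fold higher number from compound 2 to compound 4 (0.24 log units; within the scatter) toward a weaker inhibitor in this assay. Compound 4 is estimated at 9000 nM, within a range from 1500 nM to 60000 nM.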

Compound 4, half-maximal inhibitory concentration: > 100000 nM
Compound 4: no number, only a limit; the forecaster's own chance of this, stated with the estimate: 20%; middle value at least 11-fold (1.04 log units) away from the limit.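

Among the compounds shown here, the first change at the nitro position is a large one: replacing nitro with (3-hydroxycyclohexyl)amino, on an aromatic carbon meta to a large group, gives an at least 19-fold higher number from compound 2 to compound 4 (1.28 log units; beyond the scatter). In this assay compound 4 gives > 100000 nM, which is a limit of the assay and not a number, so only the lower bound of the step is known: the limit of > 100000 nM in this assay, at which 2 of the 4 values shown sit. The exchange of bromo for trifluoromethyl on the shared core, a 3.2-fold higher number from compound 1 to compound 2 (0.51 log units; beyond the scatter), stayed within measurable values, whereas this exchange on the aryl portion ends at the limit, so this position is far from indifferent to what is placed there.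

Which part of the entering group matters stays open, since the cyclohexane ring, the hydroxyl and the amino link all enter together in compound 4. A plain amino group or a nitrile on the same aromatic carbon, or a cyclohexylamino group without the hydroxyl, would help separate these parts and show whether anything other than nitro keeps a measurable value at this position.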